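Swapping an acetylpiperidine for a lactam on the amide

The source may report more compounds than this note shows. Statements on the series, on what has been measured and on what is new or still open speak of the compounds shown alone.

Measured so far:
- compound 1, `CNC(=O)c1ccncc1Nc1cc(-c2ccc3ccn(C)c3c2)c2nccnc2c1`; in an assay on lysate for inhibition of 6-phosphofructo-2-kinase/fructose-2,6-bisphosphatase 3 (Homo sapiens), with stated times of 0.5 min and 45 min (on this read-out lower numbers stand for stronger inhibition and higher numbers for weaker inhibition), compound 1 gives 7020 nM
- compound 2, `CC(=O)N1CCC(NC(=O)c2ccncc2Nc2cc(-c3ccc4ccn(C)c4c3)c3nccnc3c2)CC1`; in this assay compound 2 gives 31300 nM

Compound 2 stands highest of these two numbers, and the step of a 4.5-fold higher number from compound 1 to compound 2 (0.65 log units; beyond the scatter) places it beyond the usual scatter, so it is the weaker of the pair on this read-out. Compound 3, `Cn1ccc2ccc(-c3cc(Nc4cnccc4C(=O)NC4CCNC(=O)C4)cc4nccnc34)cc21`, takes compound 2 as its starting point. The change is 2-oxopiperidin-4-yl in place of 1-acetylpiperidin-4-yl on an amide-type nitrogen. Among the measured compounds shown here, only one measured step touches this amide nitrogen, namely a 4.5-fold higher number from compound 1 to compound 2 (0.65 log units; beyond the scatter), in which a small methyl gave way to a six-membered ring bearing an acetyl. No measured pair replaces one six-membered ring by another at this position, so the direction of the present change is not shown by the data. Since compound 3 keeps a six-membered ring with one hetero atom on the same nitrogen and exchanges only what decorates it, the expected step is a 1.3-fold lower number from compound 2 to compound 3 (0.10 log units; within the scatter), which I would place within or close to the scatter. For compound 3 my estimate is 25000 nM, with a range from 8000 nM to 80000 nM.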

Compound 3, half-maximal inhibitory concentration: 56500 nM
Compound 3: the middle estimate sits 2.3-fold (0.35 log units) below what was measured; the measured number falls inside the stated range.
By their numbers in this assay, from the lowest: compound 1; then compounds 2 and 3 (each within the scatter of the next).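

In this assay, exchanging 1-acetylpiperidin-4-yl for 2-oxopiperidin-4-yl on the amide-type nitrogen gives (a 1.8-fold higher number from compound 2 to compound 3 (0.26 log units; within the scatter)), so these two six-membered rings cannot be told apart on this read-out, even though the entering group carries a hydrogen-bond donor and the leaving group carries none. The second ring also stands apart from the small methyl of compound 1 (an 8.0-fold higher number from compound 1 to compound 3 (0.91 log units; beyond the scatter)), a step that can be set beside the earlier one (a 4.5-fold higher number from compound 1 to compound 2 (0.65 log units; beyond the scatter)), and so for both rings shown here, putting the ring in place of methyl goes with a higher number and therefore weaker inhibition. No measurement offered here gives a reason for these numbers.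

The compounds shown leave open whether this nitrogen accepts any larger group without that loss, since only methyl and two ring groups carrying a carbonyl appear on it. A plain piperidin-4-yl with a free ring amine, or a longer chain ending in a carboxylic acid, would show whether the higher numbers belong to size alone or to these particular rings.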